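Swapping the Amide Aryl Group in a Curcumin-Like Series

The source may report more compounds than this note shows. Statements on the series, on what has been measured and on what is new or still open speak of the compounds shown alone.

Of the compounds shown here, three sharing one core have been measured in a functional assay on Molt4/C8 cells (Homo sapiens) for cytotoxicity; on this read-out lower numbers stand for stronger inhibition and higher numbers for weaker inhibition. Compound 1 `O=C(/C=C/C(=O)N1C/C(=C\c2ccccc2)C(=O)/C(=C/c2ccccc2)C1)Nc1ccccc1` carries unsubstituted phenyl rings on the core and a plain phenyl on the amide nitrogen; in this assay compound 1 gives 520 nM. Compound 2 `Cc1ccc(NC(=O)/C=C/C(=O)N2C/C(=C\c3ccc([N+](=O)[O-])cc3)C(=O)/C(=C/c3ccc([N+](=O)[O-])cc3)C2)cc1` bears nitro groups on the core rings and a 4-methylphenyl on the amide nitrogen; in this assay compound 2 gives 700 nM. Compound 3 `O=C(/C=C/C(=O)N1C/C(=C\c2ccc([N+](=O)[O-])cc2)C(=O)/C(=C/c2ccc([N+](=O)[O-])cc2)C1)Nc1ccc(Cl)c(Cl)c1` keeps the nitro-bearing core and carries a 3,4-dichlorophenyl on the amide nitrogen; in this assay compound 3 gives 600 nM. Compound 3 thus stands second highest of the three numbers, yet all three sit within the scatter of one another.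

Compound 4 `O=C(/C=C/C(=O)N1C/C(=C\c2ccc([N+](=O)[O-])cc2)C(=O)/C(=C/c2ccc([N+](=O)[O-])cc2)C1)Nc1ccc([N+](=O)[O-])cc1` differs from compound 3 in one place: 4-nitrophenyl in place of 3,4-dichlorophenyl on an amide-type nitrogen. Among the compounds with values here, the only directly comparable step, a 1.2-fold lower number from compound 2 to compound 3 (0.07 log units; within the scatter), swapped one amide aryl group for another and moved the number no further than the scatter. Since the amide aryl group has so far made little difference, the step of no change at the digits printed from compound 3 to compound 4 (within the scatter) is expected to stay within the scatter as well, in no clear direction. Compound 4 is therefore estimated at 600 nM, with a range from 300 nM to 1200 nM.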

Compound 4, half-maximal inhibitory concentration: 430 nM
For compound 4 the middle estimate is 1.4-fold (0.14 log units) above the measured one; measured number inside the range.
By their numbers in this assay, from the lowest: compounds 4, 1, 3 and 2 (each within the scatter of the next).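

With compound 4, three different aryl groups have been placed on the amide-type nitrogen over the same nitro-bearing core, and in this assay none of them stands apart from the others. Putting 4-nitrophenyl in place of 3,4-dichlorophenyl gives a 1.4-fold lower number from compound 3 to compound 4 (0.14 log units; within the scatter) even though the count of hydrogen-bond acceptors on the group goes from 0 to 2, while nitro in place of methyl on the aromatic carbon gives a 1.6-fold lower number from compound 2 to compound 4 (0.21 log units; within the scatter) and so this comparison also stays small. The position has therefore accepted a methyl, two chlorines and a nitro group with no change that can be told from the scatter, and nothing available here offers an explanation for that.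

Going by these compounds, whether a group of a different kind on this aryl ring, such as an amine or a carboxylic acid, or a longer alkyl chain in place of the ring, would move the number beyond the scatter remains open. On these data alone, what the nitro groups on the core rings contribute is also open: compound 1 differs from each of the other compounds in more than one place.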